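The compounds below may be only part of what the source reports. "The series", "measured", "known", "first", "only" and "open" are said of these compounds alone.

Measured in a functional assay on SW-620 cells (Homo sapiens) for antiproliferative activity, read by MTT assay, with a stated time of 24 h; on this read-out higher numbers stand for weaker inhibition and lower numbers for stronger inhibition:
- Compound 1 `CCN(CC)c1ccc(/C=C/C(=O)c2ccc(OC)c3c2OC(C)(C)C=C3)cc1`: 670 nM
- Compound 2 `COc1ccc(C(=O)/C=C/c2ccc([N+](=O)[O-])cc2)c2c1C=CC(C)(C)O2`: 3520 nM
- Compound 3 `COc1ccc(C(=O)/C=C/c2ccccc2Cl)c2c1C=CC(C)(C)O2`: > 10000 nM (a limit of the assay, not a number)

Of these three, only compound 3 has no actual number, and its standing rests on (the limit of > 10000 nM in this assay, at which 1 of the 3 values shown sits). Compound 4 `COc1ccc(C(=O)/C=C/c2ccc(O)cc2)c2c1C=CC(C)(C)O2` keeps the shared core but carries 4-hydroxyphenyl in place of 2-chlorophenyl on a double-bonded chain carbon bound to a double-bonded chain carbon.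

Among the compounds with values here, two measured steps bear on this change. At the same place, 2-chlorophenyl replacing 4-nitrophenyl gave an at least 2.8-fold higher number from compound 2 to compound 3 (0.45 log units; beyond the scatter). Nitro replacing diethylamino on an aromatic carbon gave a 5.3-fold higher number from compound 1 to compound 2 (0.72 log units; beyond the scatter). Both steps are modest but beyond the scatter, and both point to a sensitivity to what this aromatic group carries. Leaving 2-chlorophenyl behind is therefore expected to give a modest move towards stronger inhibition in this assay. The expected change is an at least 3.3-fold lower number from compound 3 to compound 4 (0.52 log units; beyond the scatter). For compound 4 the estimated value is 3000 nM, with an expected range of 800 nM to 10000 nM.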

Compound 4, half-maximal inhibitory concentration: > 10000 nM
Compound 4 gave a limit, no number; the forecaster's own chance of this, stated with the estimate: 15%; middle value at least 3.3-fold (0.52 log units) away from the limit.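

Leaving 2-chlorophenyl behind for 4-hydroxyphenyl does not by itself bring a readable value, and compound 3 and compound 4 both stop at an assay limit, so the step between them cannot be read: the limit of > 10000 nM in this assay, at which 2 of the 4 values shown sit. The other comparisons can be read: hydroxy in place of nitro on an aromatic carbon gives an at least 2.8-fold higher number from compound 2 to compound 4 (0.45 log units; beyond the scatter), and hydroxy in place of diethylamino gives an at least 14-fold higher number from compound 1 to compound 4 (1.17 log units; beyond the scatter). Of the four compounds, only compound 1 and compound 2 give actual numbers, so at this place a readable value is tied so far to just the diethylamino and nitro groups.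

Going by these compounds, it remains open how far compound 3 and compound 4 lie beyond the limit, or whether they differ at all. On these data alone, it is also open whether a plain amine or dimethylamino on that aromatic carbon would stay close to compound 1.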